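The compounds below may be only part of what the source reports. "The series", "measured", "known", "first", "only" and "open" are said of these compounds alone.

Measured so far:
compound 1 `CCCCCCc1nc(O)cc(O)n1` gives 454 nM in a functional assay on HEK293 cells for agonist activity at G-protein coupled receptor 84 (Homo sapiens), read by calcium flux; a higher number here means that more compound is needed for the effect, a lower number that less compound is needed;
compound 2 `Cc1cc(O)nc(SCCCCc2ccccc2)n1` reaches only a limit, > 100000 nM;
compound 3 `Oc1cc(C(F)(F)F)nc(SCCCCc2ccccc2)n1` reaches only a limit, > 100000 nM.

Compound 3 therefore stands at the limit of this assay, not at a number; the limit of > 100000 nM in this assay, at which 2 of the 3 values shown sit, shows that two of the three values sit there. Among the compounds with values here, the one step between measured neighbours, a step that the two limits leave unreadable from compound 2 to compound 3, is unreadable for the same reason. Compound 4 `Nc1cc(O)nc(SCCCCc2ccccc2)n1` differs from compound 3 by amino in place of trifluoromethyl on an aromatic carbon. Within the data shown here, no measured step bears on an amino group, so nothing points to a change in this assay beyond the scatter. Compound 4 is therefore expected to give about 80000 nM (from 20000 nM to 300000 nM), most likely again only a limit. For compound 4 this estimate means a step of an at least 1.2-fold lower number from compound 3 to compound 4 (0.09 log units; that floor lies within the scatter).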

Compound 4, half-maximal effective concentration: > 100000 nM
Compound 4 gave a limit, no number; the forecaster's own chance of this, stated with the estimate: 75%; at least 1.2-fold (0.09 log units) between middle value and limit.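

Compound 2, compound 3 and compound 4 all stand at a limit, so no step among them can be read: the limit of > 100000 nM in this assay, at which 3 of the 4 values shown sit.

The compounds shown leave open whether methyl, trifluoromethyl and amino differ at all on this shared core.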